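Furanyl replacement on the carbonyl carbon of compound 3

The source may report more compounds than this note shows. Statements on the series, on what has been measured and on what is new or still open speak of the compounds shown alone.

Compound 3 `COc1ccc(-c2cc3ccccc3nc2/C=C/C(=O)c2ccc(OC)c(OC)c2)cc1` gives 3260 nM in a functional assay on SK-BR-3 cells (Homo sapiens) for antiproliferative activity, read by XTT assay, with a stated time of 72 h (on this read-out lower numbers stand for stronger inhibition and higher numbers for weaker inhibition), the lowest of the three numbers, though it sits within the scatter of compound 2 `COc1ccc(-c2cc3ccccc3nc2/C=C/C(=O)c2c(OC)cccc2OC)cc1` with 3830 nM. Compound 1 `COc1ccc(C(=O)/C=C/c2nc3ccccc3cc2-c2ccc(OC)cc2)cc1` gives 9280 nM, and the step from it to compound 3 is the only one that lies beyond the scatter. Compound 4 `COc1ccc(-c2cc3ccccc3nc2/C=C/C(=O)c2ccco2)cc1` differs from compound 3 in one place: furan-2-yl in place of 3,4-dimethoxyphenyl on a carbonyl carbon.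

All three measured steps vary the group on that same carbonyl carbon and are modest: a 2.4-fold lower number from compound 1 to compound 2 (0.38 log units; beyond the scatter), a 2.8-fold lower number from compound 1 to compound 3 (0.45 log units; beyond the scatter), and a 1.2-fold lower number from compound 2 to compound 3 (0.07 log units; within the scatter). Among the measured compounds shown here, no measured compound carries a five-membered aromatic ring on this carbon, so these steps set only the scale of such changes, not the direction for a furan-2-yl. Since compound 3 gained over compound 1 through a 2.8-fold lower number from compound 1 to compound 3 (0.45 log units; beyond the scatter), removing both methoxy groups along with the six-membered ring is expected to give back some of that, a step of a 1.8-fold higher number from compound 3 to compound 4 (0.26 log units; within the scatter). Compound 4 is therefore estimated at 6000 nM, with a range from 2500 nM to 15000 nM.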

Compound 4, half-maximal inhibitory concentration: 640 nM
Estimate against measurement, compound 4: 9.4-fold (0.97 log units) above, and the stated range ends above it.
By their numbers in this assay, from the lowest: compound 4; then compounds 3 and 2 (each within the scatter of the next); then compound 1.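

In this assay furan-2-yl on the carbonyl carbon brings a 5.1-fold lower number from compound 3 to compound 4 (0.71 log units; beyond the scatter) as well as a 6.0-fold lower number from compound 2 to compound 4 (0.78 log units; beyond the scatter) and a 15-fold lower number from compound 1 to compound 4 (1.16 log units; beyond the scatter) and so gives the lowest number of the series. Among the compounds shown here, the earlier changes on this carbon, all among methoxy-bearing phenyl groups, reached no step of this size, and a methoxy-bearing six-membered ring is clearly not required here for a lower number. Nothing measured here accounts for the lower number of compound 4.

Open, as far as these compounds go, is whether the lower number follows the ring oxygen, the five-membered ring or the smaller group. Thiophen-2-yl, pyrrol-2-yl or unsubstituted phenyl on the carbonyl carbon would separate these, and a furan-2-yl carrying a methyl group or an amine would test how much room this position allows.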